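This account rests on a few compounds, and the source may have more. Where it says the series, first, only, none or still open, it means among the compounds named here.

Measured compounds:
compound 1 `CCCCCC(C#N)O[Si](C)(C)C` — 314000 nM
compound 2 `CCCCCCCC(C#N)O[Si](C)(C)C` — 216000 nM

Both compounds were tested in an assay on isolated protein for inhibition of Phenylethanolamine N-methyltransferase (Bos taurus); a lower number here means a stronger inhibitor, a higher number a weaker inhibitor. Compound 1 gives 314000 nM, and compound 2 gives 216000 nM. The two numbers are within the scatter of each other, so compound 1 stands with the higher number of the two, without a real difference from compound 2 being shown. For the measured compounds named here, the one measured step, a 1.5-fold lower number from compound 1 to compound 2 (0.16 log units; within the scatter), changes the length of the chain and leaves the number essentially where it was.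

Compound 3 `CCCCCC(C)(C#N)O[Si](C)(C)C` has not been measured. It differs from compound 1 by methyl in place of hydrogen on a saturated chain carbon bound to an oxygen on an unsaturated carbon, a saturated chain carbon and a triple-bonded carbon. Going by the values given here, no measured step touches this carbon; the only step known here concerns the far end of the chain and was within the scatter. There is therefore no basis for expecting a large movement in either direction in this assay, and the estimate for compound 3 stays close to compound 1 with a wide range.

Compound 3 is expected to give about 300000 nM, with a likely range from 100000 nM to 900000 nM. This estimate amounts to a step of a 1.0-fold lower number from compound 1 to compound 3 (0.02 log units; within the scatter), expected to be within the scatter.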

Compound 3, half-maximal inhibitory concentration: 669000 nM
Compound 3: middle estimate off by 2.2-fold (0.35 log units), on the low side, within the range that was stated.
By their numbers in this assay, from the lowest: compounds 2 and 1 (each within the scatter of the next); then compound 3.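

In this assay, for the compounds shown here, the carbon bound to an oxygen on an unsaturated carbon, a saturated chain carbon and a triple-bonded carbon is the first place in this short series where a change moves the number beyond the usual scatter: methyl in place of hydrogen there gives a 2.1-fold higher number from compound 1 to compound 3 (0.33 log units; beyond the scatter). So adding a single carbon at this position makes the compound a somewhat weaker inhibitor, while the chain change in a 1.5-fold lower number from compound 1 to compound 2 (0.16 log units; within the scatter) showed no real difference, and the two sites therefore do not respond alike in these compounds. Nothing available here explains why the methyl has this effect.

As far as these compounds go, with only one substitution at this carbon, it remains open whether an ethyl group there would raise the number further, or whether the step seen with methyl is specific to that group. Also open, from the compounds shown here alone, is how the series would respond if the nitrile were replaced by a carboxylic acid or an amine, or if the trimethylsilyl group on the oxygen gave way to a simple hydroxyl.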